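The source may report more compounds than this note shows. Statements on the series, on what has been measured and on what is new or still open speak of the compounds shown alone.

Compound 1 `CC(C)(C)c1cc(NC(=O)Nc2cc(F)cc(F)c2)n(-c2ccccc2)n1` gives 2.5 degrees C in an assay on isolated protein for inhibition of serine/threonine-protein kinase 10 (Homo sapiens), read by thermal shift assay, tested at 10 uM; on this read-out higher numbers stand for stronger stabilisation of the target against heat and lower numbers for weaker stabilisation of the target.
Compound 2 `Cn1nc(C(C)(C)C)cc1NC(=O)Nc1cc(F)cc(F)c1` gives 1.1 degrees C in this assay.
Compound 3 `CC(C)(C)c1cc(NC(=O)Nc2ccc(Cl)cc2)n(-c2ccc(S(C)(=O)=O)cc2)n1` gives 4.1 degrees C in this assay.

Compound 3 stands highest of these three numbers; compound 1 comes nearest, and compound 2 lies furthest below, both beyond the scatter. Compound 4 `CC(C)(C)c1cc(NC(=O)Nc2ccc(Cl)cc2)n(-c2ccc(NS(C)(=O)=O)cc2)n1` differs from compound 3 in one place: methanesulfonamido in place of methylsulfonyl on an aromatic carbon. For the measured compounds named here, the only measured step, a number 1.4 degrees C lower from compound 1 to compound 2 (beyond the scatter), concerns a different part of the shared core, so it offers no direct guide to this change. With nothing closer to lean on, the change is expected to move this assay by little, if at all, beyond the scatter. The expected step of a number 0.10 degrees C lower from compound 3 to compound 4 (within the scatter) is therefore small. Compound 4 is estimated to give 4 degrees C, within a range of 2.5 degrees C to 5.5 degrees C.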

Compound 4, shift of the target's melting temperature: 8.9 degrees C
The estimate for compound 4 lay 4.9 degrees C below the measured number, outside the stated range (above it).
By their numbers in this assay, from the lowest: compound 2; then compound 1; then compound 3; then compound 4.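

Putting methanesulfonamido in place of methylsulfonyl on this aromatic carbon, para to a large group, gives a number 4.8 degrees C higher from compound 3 to compound 4 (beyond the scatter) in this assay. This position therefore responds strongly to a change of only one added nitrogen and one hydrogen-bond donor, which the earlier step on the aromatic nitrogen could not reveal. Nothing available explains why the number rises.

Going by these compounds, whether the added nitrogen or its hydrogen matters remains open. So does how an amine or a carboxylic acid would behave on this carbon.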